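Swapping the carbonyl substituent: from compound 3 to compound 4

A few compounds are considered here, and "the series" means these few. Any claim that something is new, unique, unknown or untested is made for them only; others in the source may bear on it.

Measured so far:
compound 1 `CN(C(=O)c1ccc2ncsc2c1)c1ccc(OCc2ccc3ccccc3c2)cc1` gives 48.3 mL/min/kg
compound 2 `Cn1cc(-c2ccncc2)c(-c2ccc(OCB3C=Cc4ccccc4N3)cc2)n1` gives 41.7 mL/min/kg
compound 3 `CN(C(=O)c1cc(-c2ccccn2)[nH]n1)c1ccc(OCc2ccc3ccccc3c2)cc1` gives 30 mL/min/kg

The three numbers come from an ADME assay (liver) for metabolic stability, with Liver microsome (Rattus norvegicus) as the target, using microsomes; a lower number here means slower removal, a higher number faster removal of the compound. Among the compounds with values here, compound 3 is the one with the smallest number, but it is not set apart: its nearest neighbour is compound 2 and its furthest is compound 1, and both gaps lie within the scatter of repeated measurements, so no ordering among the three can be claimed.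

Compound 4 `CN(C(=O)c1ccncc1)c1ccc(OCc2ccc3ccccc3c2)cc1` is the next compound. It differs from compound 3 in one place: pyridin-4-yl in place of 5-(pyridin-2-yl)-1H-pyrazol-3-yl on a carbonyl carbon. Within the data shown here, only one measured step bears on this change, namely the one at the same carbonyl carbon, which gave a 1.6-fold lower number from compound 1 to compound 3 (0.21 log units; within the scatter). That step, which also exchanged the whole group on the carbonyl carbon, stayed within the scatter. With nothing else to go on, the change from compound 3 to compound 4 is expected to stay within the scatter as well, in either direction, which is what a 1.2-fold higher number from compound 3 to compound 4 (0.07 log units; within the scatter) expresses. Compound 4 is therefore estimated to give 35 mL/min/kg in this assay, with a range from 20 mL/min/kg to 60 mL/min/kg.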

Compound 4, clearance: 75 mL/min/kg
Estimate against measurement, compound 4: 2.1-fold (0.33 log units) below; the whole stated range lies below it.
By their numbers in this assay, from the lowest: compounds 3, 2, 1 and 4 (each within the scatter of the next, the first and the last beyond it).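

In this assay, the group on the carbonyl carbon now proves able to shift the number: replacing 5-(pyridin-2-yl)-1H-pyrazol-3-yl with pyridin-4-yl gave a 2.5-fold higher number from compound 3 to compound 4 (0.40 log units; beyond the scatter) and passed the scatter, which the earlier step at this position, a 1.6-fold lower number from compound 1 to compound 3 (0.21 log units; within the scatter), did not do. Replacing 1,3-benzothiazol-6-yl with pyridin-4-yl at the same place gave a 1.6-fold higher number from compound 1 to compound 4 (0.19 log units; within the scatter), so the choice of group does not always separate two compounds, and among compounds 1, 3 and 4 only compound 3 and compound 4 stand clearly apart. The group that leaves differs from the one that enters in several counted features at once, with two aromatic rings against one and a hydrogen-bond donor against none, and nothing available here says what lies behind the step.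

It remains open which part of 5-(pyridin-2-yl)-1H-pyrazol-3-yl matters, as the compounds shown do not separate its pyrazole ring from its pyridine ring. Also open, going by these compounds, is how a plain phenyl, a simple amine or a carboxylic acid on this carbonyl carbon would behave in this assay on the same core.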